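Chain-extended nitriles on a tetrabrominated core in MCF7 cells

The source may hold more compounds than are shown below. What is called first, only, known or untested is meant among the compounds shown, and "the series" means these compounds.

Measured so far:
compound 1 `Cc1nc2c(Br)c(Br)c(Br)c(Br)c2n1CC#N` gives 52%
compound 2 `N#CCCn1cnc2c(Br)c(Br)c(Br)c(Br)c21` gives 81%
compound 3 `Cc1nc2c(Br)c(Br)c(Br)c(Br)c2n1CCCC#N` gives 65%

In a functional assay on MCF7 cells (Homo sapiens) for cytotoxicity, read by MTT assay, with a stated time of 24 h, tested at 10 uM (a higher number here means a weaker effect of the compound at the concentration tested, a lower number a stronger effect), compound 1 gives 52%, and compound 3 gives 65%. The change between them is 2-cyanoethyl in place of cyano on a saturated chain carbon bound to an aromatic nitrogen, and it made the step of a number 13 percentage points higher from compound 1 to compound 3 (beyond the scatter). Compound 2 has the highest number of the three; the difference between its core and that of compound 1 is not broken down here. Compound 4 `N#CCCCCn1cnc2c(Br)c(Br)c(Br)c(Br)c21` carries the change (2-cyanoethyl in place of cyano on a saturated chain carbon, two bonds along the chain from an aromatic nitrogen). The place differs: in compound 1 the saturated chain carbon is bound to an aromatic nitrogen, in compound 2 it lies two bonds along the chain from an aromatic nitrogen, so this is the same kind of change, not the same. Compound 4 is expected to show a step of a number 9 percentage points higher from compound 2 to compound 4 (within the scatter), resting on compound 1 to compound 3 giving a number 13 percentage points higher from compound 1 to compound 3 (beyond the scatter). Compound 4 is therefore estimated at 90%.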

Compound 4, a percentage reported as activity, at one concentration (the size of the read-out at that concentration, not a potency): 102%
For compound 4 the middle estimate is 12 percentage points below the measured one; the whole stated range lies below it.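

In this assay the exchange of cyano for 2-cyanoethyl gives a number 21 percentage points higher from compound 2 to compound 4 (beyond the scatter), and set beside the earlier case, the two steps point the same way and do not separate in size: the same change on two cores in this assay, a number 13 percentage points higher (beyond the scatter) from compound 1 to compound 3 and a number 21 percentage points higher (beyond the scatter) from compound 2 to compound 4, 8 percentage points apart, within the scatter of two such steps. The change therefore carried from one core to the other as a move towards a weaker effect, even though it sits at a different place on the chain in each pair. Going by these compounds alone, this rests on only two pairs at one concentration, and it does not show why the number goes up or that the step would hold on any further core.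

The compounds shown leave open whether a longer chain than 4-cyanobutyl would continue this trend. They also leave open how an amide or a carboxylic acid in place of the nitrile would read in this assay.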